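This account rests on a few compounds, and the source may have more. Where it says the series, first, only, none or still open, it means among the compounds named here.

Measured in a functional assay on MDA-MB-231 cells (Homo sapiens) for inhibition, read by sulforhodamine B assay, tested at 10 uM; a lower number here means less inhibition, a higher number more inhibition at the concentration tested (going by the name of the read-out):
compound 1, `CN(C)c1ccc(C2CC(c3ccc(-n4ccnc4)cc3)=NN2C(=O)CCCl)cc1`, gives 2.1%
compound 2, `CN(C)c1ccc(C2CC(c3ccc(-n4ccnc4)cc3)=NN2C(=O)c2ccc(F)cc2)cc1`, gives 9.4%
compound 3, `CN(C)c1ccc(C2CC(c3ccc(-n4ccnc4)cc3)=NN2C(=O)c2ccc(C(F)(F)F)cc2)cc1`, gives 17.9%

Compound 3 holds the highest of the three numbers. Among the compounds with values here, its distance to compound 2, a number 8.5 percentage points higher from compound 2 to compound 3 (within the scatter), lies within the usual scatter of this kind of measurement, so the two cannot be ordered against each other; its distance to compound 1, a number 15.8 percentage points higher from compound 1 to compound 3 (beyond the scatter), lies beyond it, and this is the only step among the three that stands out.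

Compound 4, `CN(C)c1ccc(C2CC(c3ccc(-n4ccnc4)cc3)=NN2S(=O)(=O)c2ccc([N+](=O)[O-])cc2)cc1`, is reached from compound 3 by one change: (4-nitrophenyl)sulfonyl in place of (4-(trifluoromethyl)phenyl)carbonyl on an amine nitrogen in a ring. Of the measured steps, only a number 8.5 percentage points higher from compound 2 to compound 3 (within the scatter) touches a comparable region, exchanging the substituent on the aromatic ring of the group at the ring nitrogen, and it stayed within the scatter. Within the data shown here, no measured pair exchanges a carbonyl for a sulfonyl, so the data say nothing about that part of the change. With only a small, within-scatter step to lean on, compound 4 is expected to sit close to compound 3, with a step of a number 2.9 percentage points lower from compound 3 to compound 4 (within the scatter), which means no movement beyond the scatter. The estimate for compound 4 is therefore 15%, with a range from 3% to 32%.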

Compound 4, a percentage reported as inhibition, at one concentration (the size of the read-out at that concentration, not a potency): 41.5%
Compound 4: the middle estimate sits 26.5 percentage points below what was measured; the whole stated range lies below it.
By their numbers in this assay, from the lowest: compounds 1, 2 and 3 (each within the scatter of the next, the first and the last beyond it); then compound 4.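

In this assay, the group on the amine nitrogen in the ring matters more than the compounds with a carbonyl there had shown: the change to (4-nitrophenyl)sulfonyl gives a number 23.6 percentage points higher from compound 3 to compound 4 (beyond the scatter), and the same exchange at the other two compounds gives a number 32.1 percentage points higher from compound 2 to compound 4 (beyond the scatter) and a number 39.4 percentage points higher from compound 1 to compound 4 (beyond the scatter). All three steps lie beyond the scatter, whereas among the carbonyl compounds only the step between the 2-chloroethyl and 4-(trifluoromethyl)phenyl groups did, so compound 4 stands clear of every other compound shown. No measurement at hand accounts for this rise.

The compounds shown leave open whether the sulfonyl or the nitro group carries the step, since the two enter together and the aromatic substituent changes along with the link; a (4-nitrophenyl)carbonyl or a (4-fluorophenyl)sulfonyl group on the same nitrogen would separate them. Also open, as far as these compounds go, is whether the number holds with a methylsulfonyl group at this position, or with an amine in place of the nitro group on the aromatic ring.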